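The source may report more compounds than this note shows. Statements on the series, on what has been measured and on what is new or still open speak of the compounds shown alone.

Measured so far:
- Compound 1 `CC(C)c1cc2c3c(c1OC(=O)CCl)OC(=O)[C@@]31CCCC(C)(C)[C@@H]1CC2`: 103000 nM
- Compound 2 `CCCCCCCCCCCC(=O)Oc1c(C(C)C)cc2c3c1OC(=O)[C@@]31CCCC(C)(C)[C@@H]1CC2`: 413000 nM

Going by the values given here, in an ADME assay on AGS cells (Homo sapiens) for cytotoxicity, read by neutral red uptake, with a stated time of 24 h (a higher number here means a weaker inhibitor, a lower number a stronger inhibitor), compound 2 gives 413000 nM, the higher of only two numbers, and compound 1 is its sole neighbour. Among the compounds with values here, the next compound, compound 3 `CC(C)c1cc2c3c(c1OC(=O)c1ccccc1)OC(=O)[C@@]31CCCC(C)(C)[C@@H]1CC2`, keeps the shared core and alters only one group: phenyl in place of undecyl on a carbonyl carbon.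

Within the data shown here, one measured step bears on this change, since it also alters the group carried by that carbonyl carbon: a 4.0-fold higher number from compound 1 to compound 2 (0.60 log units; beyond the scatter). This step is modest but beyond the scatter, so a change here can move the number. Among the measured compounds shown here, no measured compound carries a ring on that carbonyl carbon, so the effect of phenyl remains uncertain. With the long chain gone, a move back toward compound 1 at 103000 nM is expected, probably without passing it by much.

The estimated change is a 2.4-fold lower number from compound 2 to compound 3 (0.39 log units; beyond the scatter), toward a lower number. For compound 3 the expected value is 170000 nM, within an estimated range of 70000 nM to 420000 nM.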

Compound 3, half-maximal inhibitory concentration: 503000 nM
Compound 3: middle estimate off by 3.0-fold (0.47 log units), on the low side, outside the stated range (above it).
By their numbers in this assay, from the lowest: compound 1; then compounds 2 and 3 (each within the scatter of the next).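

In this assay the swap of undecyl for phenyl on a carbonyl carbon gives a 1.2-fold higher number from compound 2 to compound 3 (0.09 log units; within the scatter) and so lies within the scatter: a long open chain and a six-membered aromatic ring of carbon only cannot be told apart here. Compound 1, which carries chloromethyl on that same carbonyl carbon, now stands apart from both, with a 4.9-fold higher number from compound 1 to compound 3 (0.69 log units; beyond the scatter) as the new comparison, so the higher number seen for compound 2 does not depend on a long chain, since compound 3 has none. No measurement at hand gives a reason for this split between chloromethyl and the other two groups.

Going by these compounds alone, with only three groups on this carbonyl carbon, it remains open whether the chlorine atom is what sets compound 1 apart or whether any short group would do the same, a question that a plain methyl or an ethyl group in its place could settle. A chain ending in an amine or a carboxylic acid, or a phenyl ring bearing a chlorine atom, would show whether this position responds to anything beyond the chloromethyl group.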